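The compounds below may be only part of what the source reports. "The series", "measured", "known", "first", "only" and "open" are said of these compounds alone.

Compound 1 `CC(C)(C)c1ccc(C(=O)N2CCC3(CC2)C(=O)N(CC(=O)N2CCCCC2CCO)CN3c2ccccc2)cc1` gives 6100 nM in an assay on HEK293 cells for displacement of a labelled ligand from NPC1-like intracellular cholesterol transporter 1 (Homo sapiens); a lower number here means a stronger inhibitor, a higher number a weaker inhibitor. Compound 2 `CC(C)(C)OC(=O)NC1CCN(C(=O)CN2CN(c3ccccc3)C3(CCN(C(=O)c4ccc(C5CCCCC5)cc4)CC3)C2=O)CC1` gives 4800 nM in this assay. Compound 3 `O=C(CN1CN(c2ccccc2)C2(CCN(C(=O)c3ccc(C4CCCCC4)cc3)CC2)C1=O)NCCO` gives 2000 nM in this assay.

Of the three numbers, that of compound 1 is the highest. Compound 2 lies nearest to it, and the gap between the two is within the scatter, so nothing separates them. Compound 3 lies furthest away, with a lower number that sits beyond the scatter. Going by the values given here, compound 2 and compound 3 differ from compound 1 in more than one place, so no single step between measured compounds is available.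

Compound 4 `CC1(C)CC(OC(=O)CN2CN(c3ccccc3)C3(CCN(C(=O)c4ccc(C(C)(C)C)cc4)CC3)C2=O)CC(C)(C)N1` differs from compound 1 in one place: (2,2,6,6-tetramethylpiperidin-4-yl)oxy in place of 2-(2-hydroxyethyl)piperidin-1-yl on a carbonyl carbon. The carbonyl carbon that carried an amide in compound 1 thus carries an ester in compound 4, and the ring that enters is the larger of the two.

Among the compounds with values here, with no measured step to lean on, the expected effect of this change on compound 4 is modest and in no clear direction, most likely none beyond the scatter, which is what a 1.4-fold lower number from compound 1 to compound 4 (0.13 log units; within the scatter) is meant to express. Compound 4 is therefore estimated at 4500 nM, with a range from 1300 nM to 14000 nM.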

Compound 4, half-maximal inhibitory concentration: 1300 nM
Compound 4: the middle estimate sits 3.5-fold (0.54 log units) above what was measured; low and high end bracket the measured number.
By their numbers in this assay, from the lowest: compounds 4 and 3 (each within the scatter of the next); then compounds 2 and 1 (each within the scatter of the next).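

Going by these compounds alone, the replacement of 2-(2-hydroxyethyl)piperidin-1-yl by (2,2,6,6-tetramethylpiperidin-4-yl)oxy provides the first single-place comparison in this assay, and it reads a 4.7-fold lower number from compound 1 to compound 4 (0.67 log units; beyond the scatter). Compounds 1, 2 and 3 differ from one another in more than one place, so they could not show that this position, on a carbonyl carbon whose other neighbour is a saturated chain carbon, responds to what is placed on it. The step changes an amide to an ester and also exchanges one ring-bearing group for another, and nothing measured here bears on why the number moved.

The compounds shown leave open whether the step belongs to the ester oxygen or to the ring, a question that (2,2,6,6-tetramethylpiperidin-4-yl)amino on the same carbonyl carbon, or a piperidin-4-yloxy group lacking the methyl groups, would help to settle. They also leave open whether the same replacement would give a similar step in a compound carrying cyclohexyl in place of tert-butyl.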